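A few compounds are considered here, and "the series" means these few. Any claim that something is new, unique, unknown or untested is made for them only; others in the source may bear on it.

Measured compounds:
Compound 1 `CC(C)C(NC(=O)C(CC(=O)O)NC(=O)CCCOc1ccc(C(=N)N)cc1)C(=O)O` gives 1.29 in a physicochemical assay for lipophilicity; on this read-out higher numbers stand for higher lipophilicity and lower numbers for lower lipophilicity.
Compound 2 `CC(C)(C)CC(NC(=O)C(CC(=O)O)NC(=O)CCCOc1ccc(C(=N)N)cc1)C(=O)O` gives 1.59 in this assay.
Compound 3 `N=C(N)c1ccc(OCCCCC(=O)NC(CC(=O)O)C(=O)NC(CO)C(=O)O)cc1` gives 0.904 in this assay.

Among these three numbers compound 1 stands second highest. Its nearest neighbour is compound 2, reached by the step of a number 0.30 log units higher from compound 1 to compound 2 (within the scatter), which the scatter swallows. Among the compounds with values here, compound 3 lies further off; no step is drawn between compound 3 and compound 1, and its value simply sits lower than that of compound 1, by more than the scatter.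

The unmeasured compound 4 `CC(C)C(C)NC(=O)C(CC(=O)O)NC(=O)CCCOc1ccc(C(=N)N)cc1` differs from compound 1 by one change: methyl in place of carboxy on a saturated chain carbon bound to an amide-type nitrogen and a saturated chain carbon. Within the data shown here, no measured step covers this change. Among the measured compounds shown here, the only step that touches the same region of the core, the one from compound 1 to compound 2, swaps one alkyl group for another and moves the number by a number 0.30 log units higher from compound 1 to compound 2 (within the scatter). The change to compound 4 is of a different kind, removing a hydrogen-bond donor and acceptor, so the measured steps give no direct anchor.

The account therefore expects compound 4 to rise in this assay by a number 1.01 log units higher from compound 1 to compound 4 (beyond the scatter), beyond the scatter, and estimates for compound 4 a value of 2.3, within the range 1.6 to 3.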

Compound 4, partition coefficient: 1.2
For compound 4 the middle estimate is 1.10 log units above the measured one; measured number below the stated range.
By their numbers in this assay, from the lowest: compounds 3, 4, 1 and 2 (each within the scatter of the next, the first and the last beyond it).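

In this assay the exchange of carboxy for methyl on a saturated chain carbon bound to an amide-type nitrogen and a saturated chain carbon appears as a number 0.09 log units lower from compound 1 to compound 4 (within the scatter) and so cannot be told apart from no change. Losing the carboxy at this place therefore leaves no resolved mark on this read-out, something the earlier compounds could not show. The larger step of a number 0.39 log units lower from compound 2 to compound 4 (beyond the scatter) does exceed the scatter, but it puts 1,2-dimethylpropyl in place of 1-carboxy-3,3-dimethylbutyl on an amide-type nitrogen, so it changes the alkyl part and the carboxy together.

From the compounds shown here alone, whether an amine, a primary amide or a hydroxymethyl at this place would behave as methyl does remains open, as does the same exchange on compound 2 or compound 3. Nothing given here offers a reason for this result.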